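From 3-methoxyphenyl to 2-ethoxyphenyl on the shared core

The source may report more compounds than this note shows. Statements on the series, on what has been measured and on what is new or still open speak of the compounds shown alone.

- compound 1 `O=C1C(Nc2ccccc2F)=CC(=O)c2c1nc1n2[C@H]2OC[C@@H](O)[C@H]2OC1` gives 9820 nM
- compound 2 `COc1cccc(NC2=CC(=O)c3c(nc4n3[C@H]3OC[C@@H](O)[C@H]3OC4)C2=O)c1` gives > 8000 nM
- compound 3 `CCOc1ccccc1NC1=CC(=O)c2c(nc3n2[C@H]2OC[C@@H](O)[C@H]2OC3)C1=O` has not yet been measured

These readings come from a functional assay on HeLa cells (Homo sapiens) for inhibition, read by sulforhodamine B assay; on this read-out lower numbers stand for stronger inhibition and higher numbers for weaker inhibition. For compound 2 the entry > 8000 nM is a limit of the assay and not a number, so compound 2 has no exact position. Compound 3 differs from it by 2-ethoxyphenyl in place of 3-methoxyphenyl on an amine nitrogen, with 2-ethoxyphenyl in place of 3-methoxyphenyl on an amine nitrogen. Going by the values given here, only one measured step bears on this change, at the same amine nitrogen: a step that the limit leaves unreadable from compound 1 to compound 2. It offers no size to carry over. Among the compounds with values here, the only number nearby is that of compound 1 at 9820 nM, so no step beyond the scatter is expected in this assay and no direction can be stated. The expected step is a step that the limit leaves unreadable from compound 2 to compound 3. Compound 3 is estimated at 9000 nM, with an expected range from 4000 nM to 20000 nM.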

Compound 3, half-maximal inhibitory concentration: 8300 nM
Compound 3: the middle estimate sits 1.1-fold (0.04 log units) above what was measured, and the stated range covers the measured number.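

With 2-ethoxyphenyl on the amine nitrogen, compound 3 gives an exact number in this assay and shows that ethoxy in place of fluoro on an aromatic carbon gives a 1.2-fold lower number from compound 1 to compound 3 (0.07 log units; within the scatter) on the shared core, so these two groups are not told apart on this read-out. For compound 2 the entry > 8000 nM is a limit of the assay and not a number. The steps that involve compound 2 cannot be read, so 2-ethoxyphenyl and 3-methoxyphenyl cannot be ranked, because compound 2 sits at that limit: the limit of > 8000 nM in this assay, at which 1 of the 3 values shown sits.

The compounds shown leave open whether any group on this amine nitrogen moves the number beyond the scatter. From the compounds shown here alone, whether a longer chain in place of ethoxy, or an amine or a carboxylic acid on the phenyl ring, would do so also stays open.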